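Two tolyl alkynes on a shared core, and a third

A few compounds are considered here, and "the series" means these few. Any claim that something is new, unique, unknown or untested is made for them only; others in the source may bear on it.

Measured so far:
compound 1, `Cc1ccc(C#Cc2ccc3c(n2)CCN(C2CCCC2)C3=O)cc1`, in an assay on HEK293 cells for displacement of a labelled ligand from metabotropic glutamate receptor 5 (Homo sapiens), with a stated time of 2 h; a higher number here means a weaker inhibitor, a lower number a stronger inhibitor: > 32000 nM
compound 2, `Cc1ccccc1C#Cc1ccc2c(n1)CCN(C1CCCCC1)C2=O`, in this assay: > 32000 nM

For compound 2 the recorded value is a limit of the assay, not a number. For compound 1 the recorded value is also a limit. Going by the values given here, both sit at the limit of > 32000 nM in this assay, at which 2 of the 2 values shown sit, so no order between them can be read, and no step between measured compounds is available.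

Compound 3, `Cc1ccc(C#Cc2ccc3c(n2)CCN(C2CCCCC2)C3=O)cc1`, is not yet measured. It differs from compound 2 by 4-methylphenyl in place of 2-methylphenyl on a triple-bonded carbon; the two have the same atoms, joined differently. Compound 1 carries the same 4-methylphenyl as compound 3 and also gives only a limit. Among the compounds with values here, no measured compound returns a number inside the range of this assay, so no step beyond the scatter is expected in either direction. Compound 3 is therefore expected to sit at a limit too, estimated at 32000 nM with a range of 10000 nM to 100000 nM. The expected step is a number no higher from compound 2 to compound 3 (the limit leaves the size open), that is, none beyond the scatter.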

Compound 3, inhibition constant: 27200 nM
Compound 3: middle estimate off by 1.2-fold (0.07 log units), on the high side; low and high end bracket the measured number.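

In this assay, going by these compounds alone, compound 3 is the first of the series to return a number rather than a limit, so both the change at the triple-bonded carbon and the change at the amide-type nitrogen now carry a step. 4-Methylphenyl in place of 2-methylphenyl gives an at least 1.1-fold lower number from compound 2 to compound 3 (0.07 log units; that floor lies within the scatter), and cyclohexyl in place of cyclopentyl gives an at least 1.1-fold lower number from compound 1 to compound 3 (0.07 log units; that floor lies within the scatter). Each step has a limit at one end and is only a floor, so neither change is shown to act beyond the scatter, and neither is ruled out: the limit of > 32000 nM in this assay, at which 2 of the 3 values shown sit.

Going by these compounds, the true size of both steps stays open, as no number is available for compound 1 or compound 2. Also open, on these data alone, is whether a methoxy or a chlorine in place of the methyl, or an isopropyl on the amide-type nitrogen, would give a clearly lower number.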